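Mirror-image urea: the other hand of compound 2

This account rests on a few compounds, and the source may have more. Where it says the series, first, only, none or still open, it means among the compounds named here.

Measured so far:
compound 1, `C[C@H](NC(=O)Nc1ccc(F)cc1F)c1ccccc1`, 101%
compound 2, `Cc1ccc(NC(=O)N[C@H](C)c2ccccc2)c(F)c1`, 98%

In an ADME assay on the whole organism with Oryza sativa as the target, tested at 0.1 uM (a higher number here means a weaker effect of the compound at the concentration tested, a lower number a stronger effect), compound 1 gives 101%. In this assay compound 2 gives 98%, and the two values lie within the usual scatter of each other, so neither compound shows a stronger effect than the other. Within the data shown here, compound 3, `Cc1ccc(NC(=O)N[C@@H](C)c2ccccc2)c(F)c1`, has not yet been measured. the two compounds have the same atoms and bonds and differ only in configuration as drawn: 1 of 1 stereo elements differ; a stereocentre at a saturated chain carbon is drawn R in compound 2 and S in compound 3 With no step between measured compounds to lean on, and both known values near the top of the scale, a step of no size beyond the scatter is expected, in either direction. The step of a number 1 percentage points lower from compound 2 to compound 3 (within the scatter) is expected to stay inside that scatter. Compound 3 is therefore expected to give about 97%, between 85% and 106%.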

Compound 3, a percentage reported as activity, at one concentration (the size of the read-out at that concentration, not a potency): 100%
Beside the measured number, compound 3's estimate is 3 percentage points below it; measured number inside the range.
By their numbers in this assay, from the lowest: compounds 2, 3 and 1 (each within the scatter of the next).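

Reversing the hand at the saturated chain carbon gives a number 2 percentage points higher from compound 2 to compound 3 (within the scatter) in this assay, so at this centre the two mirror forms cannot be told apart, and the only structural change behind that step is this: the fact that compounds 2 and 3 differ only in the configuration as drawn. The swap of fluoro for methyl on an aromatic carbon gives a number 1 percentage points lower from compound 1 to compound 3 (within the scatter), so it too leaves no mark when read with the S centre in place.

As far as these compounds go, whether any change to the shared core can move this read-out stays open. A carboxylic acid or an amine on the aromatic ring, or a longer chain in place of the methyl at the stereocentre, remains untested among the compounds shown here.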